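Swapping Phenyl for Methyl on the Second Core

A few compounds are considered here, and "the series" means these few. Any claim that something is new, unique, unknown or untested is made for them only; others in the source may bear on it.

Among the compounds with values here, compound 3 `O=C(NCCCCc1ccccc1)n1cc(-c2ccccc2)oc1=O` gives 90 nM in an assay on isolated protein for inhibition of acid ceramidase (Homo sapiens), read by LC-MS, with a stated time of 1 h (a higher number here means a weaker inhibitor, a lower number a stronger inhibitor), the highest of the three numbers measured so far. Compound 1 `O=C(NCCCCc1ccccc1)n1c(-c2ccccc2)coc1=O` gives 70 nM, which lies within the scatter of compound 3, while compound 2 `CCCCCNC(=O)n1c(-c2ccccc2)coc1=O` gives 25 nM, a gap beyond the scatter. Compound 4 `CCCCCNC(=O)n1cc(-c2ccccc2)oc1=O` differs from compound 3 by methyl in place of phenyl on a saturated chain carbon, four bonds along the chain from an amide-type nitrogen. The same change has been measured once, on the core of compound 1 rather than that of compound 3: a 2.8-fold lower number from compound 1 to compound 2 (0.45 log units; beyond the scatter). Within the data shown here, that single step is the only guide, and a step of about the same size and direction is therefore expected, a 2.8-fold lower number from compound 3 to compound 4 (0.45 log units; beyond the scatter). Compound 4 is expected to give 32 nM, with a range from 15 nM to 70 nM.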

Compound 4, half-maximal inhibitory concentration: 39 nM
The estimate for compound 4 lay 1.2-fold (0.09 log units) below the measured number; the range from low to high includes it.
By their numbers in this assay, from the lowest: compounds 2, 4, 1 and 3 (each within the scatter of the next, the first and the last beyond it).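

With methyl in place of phenyl on a saturated chain carbon, four bonds along the chain from an amide-type nitrogen, the number also falls on a second core, a 2.3-fold lower number from compound 3 to compound 4 (0.36 log units; beyond the scatter). Until now, this change had been seen on one core only. The two steps agree in direction and closely in size: the same change on two cores in this assay, a 2.8-fold lower number (0.45 log units; beyond the scatter) from compound 1 to compound 2 and a 2.3-fold lower number (0.36 log units; beyond the scatter) from compound 3 to compound 4, 1.2-fold (0.08 log units) apart, within the scatter of two such steps

The compounds shown compare only phenyl and methyl at this place, so what an amine, a carboxylic acid or a longer chain there would give remains open. Why methyl gives the lower number also remains open.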